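A few compounds are considered here, and "the series" means these few. Any claim that something is new, unique, unknown or untested is made for them only; others in the source may bear on it.

Working notes on the series. Compound 1 `Nc1cc(N)c2nc(-c3ccccc3)c(Oc3ccc(Cl)c(Cl)c3)nc2c1` carries a 3,4-dichlorophenoxy group on the shared core; in a functional assay on SF-295 cells (Homo sapiens) for inhibition, read by sulforhodamine B assay, with a stated time of 48 h (on this read-out higher numbers stand for lower toxicity in this test and lower numbers for higher toxicity in this test), compound 1 gives 69200 nM. Compound 3 `COc1ccc(CNc2nc3cc(N)cc(N)c3nc2-c2ccccc2)cc1OC` gives 58900 nM in this assay, and the two values sit within the scatter of each other, so no order between compound 1 and compound 3 is read from them. Compound 2 `CCOC(=O)[C@H](CCC(=O)O)NC(=O)c1ccc(CNc2nc3cc(N)cc(N)c3nc2-c2ccccc2)cc1` reaches only a limit in this assay, < 100000 nM, which is the limit of < 100000 nM in this assay, at which 1 of the 3 values shown sits. Compound 4 `Nc1cc(N)c2nc(-c3ccccc3)c(Oc3ccc(F)cc3)nc2c1` is not yet measured; it differs from compound 1 by 4-fluorophenyl in place of 3,4-dichlorophenyl on an oxygen on an aromatic ring. Among the compounds with values here, no measured pair shows this change, so no direction beyond the scatter is expected. The step from compound 1 to compound 4 is estimated at a 1.2-fold higher number from compound 1 to compound 4 (0.06 log units; within the scatter) in this assay. Compound 4 is therefore expected to give about 80000 nM, within 30000 nM to 200000 nM.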

Compound 4, concentration lethal to 50% of the cells: 72400 nM
Estimate against measurement, compound 4: 1.1-fold (0.04 log units) above, and the stated range covers the measured number.
By their numbers in this assay, from the lowest: compounds 3, 1 and 4 (each within the scatter of the next).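

Within the data shown here, the first measured pair at this position reads a 1.0-fold higher number from compound 1 to compound 4 (0.02 log units; within the scatter) in this assay, for 4-fluorophenyl in place of 3,4-dichlorophenyl on an oxygen on an aromatic ring. The group on that oxygen can therefore go from 3,4-dichlorophenoxy to 4-fluorophenoxy with no readable difference in this read-out. Nothing measured here bears on a cause for this step.

On these data alone, it stays open whether a longer alkyl chain on that oxygen, or an amine or a carboxylic acid on the phenyl ring, would move the number beyond the scatter.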